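This account rests on a few compounds, and the source may have more. Where it says the series, first, only, none or still open, it means among the compounds named here.

In an ADME assay on Vero cells (Chlorocebus sabaeus) for cytotoxicity, read by CellTiter-Glo, with a stated time of 72 h (a lower number here means that less compound is tolerated, a higher number that more compound is tolerated), compound 1 (`[O-][n+]1nc(NC2CC2)[n+]([O-])c2ccccc21`) gives 21 ug/mL, compound 2 (`C[C@@H](Nc1n[n+]([O-])c2ccccc2[n+]1[O-])C1CCCCC1`) gives 8.9 ug/mL, and compound 3 (`[O-][n+]1nc(NC2CC2)[n+]([O-])c2ccc(F)cc21`) gives 1.3 ug/mL, the lowest of the three numbers. Compound 4 (`COCC(C)Nc1n[n+]([O-])c2cc(F)ccc2[n+]1[O-]`) keeps the fluoro group of compound 3 and changes one substituent: 1-(methoxymethyl)ethyl in place of cyclopropyl on a nitrogen on an aromatic ring. Put simply, 1-(methoxymethyl)ethyl stands in place of cyclopropyl on a nitrogen on an aromatic ring. Within the data shown here, the one measured step, a 16-fold lower number from compound 1 to compound 3 (1.21 log units; beyond the scatter), is large, but it concerns the fluoro group, not this substituent. Among the measured compounds shown here, no measured step covers this exact swap. The nearest guide is a pair differing only in the group on that nitrogen: compound 1 at 21 ug/mL and compound 2 at 8.9 ug/mL, values far closer together than the ends of the fluoro step. A step within the scatter, with no clear direction, is therefore expected: a 1.3-fold higher number from compound 3 to compound 4 (0.12 log units; within the scatter). The estimate for compound 4 is 1.7 ug/mL, with an expected range of 0.6 ug/mL to 5 ug/mL.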

Compound 4, half-maximal cytotoxic concentration: 6.3 ug/mL
Beside the measured number, compound 4's estimate is 3.7-fold (0.57 log units) below it, and the stated range ends below it.
By their numbers in this assay, from the lowest: compound 3; then compounds 4 and 2 (each within the scatter of the next); then compound 1.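

On a nitrogen on an aromatic ring, the group itself makes a measurable difference in this assay: 1-(methoxymethyl)ethyl in place of cyclopropyl gives a 4.8-fold higher number from compound 3 to compound 4 (0.69 log units; beyond the scatter) with the fluoro group kept. Among these compounds, the only step known before concerned the fluoro group, so this is the first sign that more compound is tolerated after a change at this nitrogen. Nothing available explains this step. As far as these compounds go, whether the same swap gives a similar step without the fluoro group remains open. So does the result of putting an amine or a carboxylic acid on this nitrogen's substituent.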